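The source may report more compounds than this note shows. Statements on the series, on what has been measured and on what is new or still open speak of the compounds shown alone.

Of the compounds shown here, three from this series have so far been tested in a functional assay on HeLa cells (Homo sapiens) for cytotoxicity, read by MTT assay, with a stated time of 72 h, tested at 30 uM; on this read-out lower numbers stand for less inhibition of growth and higher numbers for more inhibition of growth at the one concentration tested. Compound 1 `N/C(=N\NC(=S)N1CCCCCC1)c1ccccn1` gives 82.9%. Compound 2 `N/C(=N\NC(=S)N1CCOCC1)c1ccccn1` gives 82.8%, a number close to that of compound 1; the difference between the two cores is not broken down here. Compound 3 `N/C(=N\NC(=S)N1CCOCC1)c1ccc(F)cn1` gives 84.5%. Compound 3 differs from compound 2 in one place, (fluoro in place of hydrogen on an aromatic carbon), and this change made a step of a number 1.7 percentage points higher from compound 2 to compound 3 (within the scatter), so the three values sit together within the usual scatter of the measurement.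

Compound 4 `N/C(=N\NC(=S)N1CCCCCC1)c1ccc(F)cn1` has not yet been measured. It differs from compound 1 by fluoro in place of hydrogen on an aromatic carbon, the same change that leads from compound 2 to compound 3, made on a different core. Compound 4 is expected to give about 84% in this assay, because compound 1 gives 82.9% and the same change earlier gave a number 1.7 percentage points higher from compound 2 to compound 3 (within the scatter). The expected range for compound 4 runs from 75% to 92%. This estimate for compound 4 amounts to an expected step of a number 1.1 percentage points higher from compound 1 to compound 4 (within the scatter).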

Compound 4, percent growth inhibition at one concentration: 84.5%
The estimate for compound 4 lay 0.5 percentage points below the measured number, within the range that was stated.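

In this assay, fluoro in place of hydrogen on an aromatic carbon makes a step of a number 1.6 percentage points higher from compound 1 to compound 4 (within the scatter), and this step agrees with the one seen on the other core: the same change on two cores in this assay, a number 1.7 percentage points higher (within the scatter) from compound 2 to compound 3 and a number 1.6 percentage points higher (within the scatter) from compound 1 to compound 4, 0.1 percentage points apart, within the scatter of two such steps

So on these two cores the change behaves alike, in that neither step stands out from the ordinary spread of the measurement. This does not show that fluoro has a real effect on growth inhibition that travels from core to core: two steps within the scatter show only that no effect could be seen on either core at the one concentration tested, and they say nothing about any other core.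

The compounds shown leave open what a different group at the same place would do, such as chloro, methoxy or an amine. They also leave open whether fluoro would give a similar result elsewhere on the ring, or at lower concentrations, where differences between the compounds might become visible.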